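The compounds below may be only part of what the source reports. "The series", "measured", "known", "first", "only" and "open" are said of these compounds alone.

Of the compounds shown here, three sharing one core have been measured in a functional assay on DU-145 cells (Homo sapiens) for inhibition, read by sulforhodamine B assay, with a stated time of 48 h; on this read-out higher numbers stand for weaker inhibition of growth and lower numbers for stronger inhibition of growth. Compound 1 `O=C(Nc1cccc(-n2cc(-c3ccncc3)c(-c3ccc(Cl)c(O)c3)n2)c1)Nc1cccc(C(F)(F)F)c1` gives 1760 nM. Compound 2 `COc1cc(-c2nn(-c3cccc(NC(=O)c4cccc(C(F)(F)F)c4)c3)cc2-c2ccncc2)ccc1Cl` gives 1760 nM, level with compound 1 at the digits shown, and together these two are the highest of the three numbers. Within the data shown here, compound 3 `O=C(Nc1cccc(-n2cc(-c3ccncc3)c(-c3ccc(Cl)c(O)c3)n2)c1)Nc1ccc(Cl)c(Cl)c1` gives 1500 nM; the one step measured so far, a 1.2-fold lower number from compound 1 to compound 3 (0.07 log units; within the scatter), swaps one aryl group on an amide-type nitrogen for another and stays within the scatter.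

Compound 4 `COc1cc(-c2nn(-c3cccc(NC(=O)Nc4cccc(C(F)(F)F)c4)c3)cc2-c2ccncc2)ccc1Cl` is the next compound to be tested. It differs from compound 2 by (3-(trifluoromethyl)phenyl)amino in place of 3-(trifluoromethyl)phenyl on a carbonyl carbon. Among the measured compounds shown here, no measured step exchanges an amide for a urea in this way, so the only guide is that compound 1, a urea, and compound 2, an amide, show the same number. On that basis the expected step is a 1.0-fold lower number from compound 2 to compound 4 (0.02 log units; within the scatter), a change of no size beyond the scatter. Compound 4 is therefore estimated at 1700 nM in this assay, with a range from 800 nM to 3600 nM.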

Compound 4, concentration for 50% growth inhibition: 1670 nM
Estimate against measurement, compound 4: 1.0-fold (0.01 log units) above; the measured number falls inside the stated range.
By their numbers in this assay, from the lowest: compounds 3, 4, 1 and 2 (each within the scatter of the next).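

Putting (3-(trifluoromethyl)phenyl)amino in place of 3-(trifluoromethyl)phenyl on the carbonyl carbon turns an amide into a urea and adds one hydrogen-bond donor, and in this assay this gives a 1.1-fold lower number from compound 2 to compound 4 (0.02 log units; within the scatter). The amide and the urea are therefore not told apart by this read-out when the rest of the molecule stays the same. Methyl in place of hydrogen on an oxygen on an aromatic ring, read within the urea compounds, gives a 1.1-fold lower number from compound 1 to compound 4 (0.02 log units; within the scatter), so that exchange cannot be told apart here either, and nothing available explains why these exchanges make so little difference.

Every step shown stays within the scatter, so it remains open whether any change at this carbonyl carbon can move the number beyond it. A carbamate, with oxygen in place of the amino nitrogen, or a simple methylene in that place would test how much the link itself matters.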